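The source may report more compounds than this note shows. Statements on the series, on what has been measured and on what is new or still open speak of the compounds shown alone.

Working notes on the series, read in an ADME assay on P388D1 cells (Mus musculus) for cytotoxicity, read by fluorescence and resazurin assay, with a stated time of 72 h; a higher number here means a weaker inhibitor, a lower number a stronger inhibitor. Compound 1 (`O=C(CCC1CCCCC1)Nc1ncc(Cc2ccccn2)s1`) gives > 40000 nM, which is a limit of the assay and not a number. For compound 2 (`O=C(CCC1CCCCC1)Nc1ncc(Cc2ccnc3ccccc23)s1`) the entry reads "not determined" (no result reported). Compound 3 (`O=C(Nc1ncc(Cc2cccc3ccoc23)s1)C1CCCCC1`) gives > 40000 nM, which is likewise only a limit. Compound 3 therefore has no single number, and its place is the limit of > 40000 nM in this assay, at which 2 of the 3 values shown sit.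

Compound 4 (`O=C(CCC1CCCCC1)Nc1ncc(Cc2cccc3ccoc23)s1`) differs from compound 3 by one change: 2-cyclohexylethyl in place of cyclohexyl on a carbonyl carbon. In words, 2-cyclohexylethyl stands in place of cyclohexyl on a carbonyl carbon. The same 2-cyclohexylethyl group is carried by compound 1, and its limit of > 40000 nM is the nearest guide available. No change beyond the usual scatter is therefore expected in this assay. The expected step is an at least 1.1-fold lower number from compound 3 to compound 4 (0.05 log units; that floor lies within the scatter). For compound 4 the estimated value is 35000 nM, with an expected range of 15000 nM to 45000 nM, and a report of only a limit is considered likely.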

Compound 4, half-maximal inhibitory concentration: 17800 nM
Compound 4: the middle estimate sits 2.0-fold (0.29 log units) above what was measured, within the range that was stated.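

In this assay, among these compounds, 2-cyclohexylethyl in place of cyclohexyl on a carbonyl carbon gives the first step that can be read at this position: an at least 2.2-fold lower number from compound 3 to compound 4 (0.35 log units; beyond the scatter). That size is only a floor, and the true gap may be larger. Compound 4 thus gives a single number in a series where the other readings do not, and the limit still dominates what is shown: the limit of > 40000 nM in this assay, at which 2 of the 4 values shown sit.

Open, going by these compounds, is whether a longer chain, such as 3-cyclohexylpropyl, or an amine in the chain on the same carbonyl carbon would move the number further. Compound 1 also carries 2-cyclohexylethyl and gives > 40000 nM, a limit of the assay, which leaves open how far this step holds on other cores.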